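This account rests on a few compounds, and the source may have more. Where it says the series, first, only, none or still open, it means among the compounds named here.

Of the compounds shown here, three of a shared core have been measured in a functional assay on ACHN cells (Homo sapiens) for inhibition, read by sulforhodamine B assay, with a stated time of 48 h; a higher number here means a weaker inhibitor of growth, a lower number a stronger inhibitor of growth. Compound 1 `COc1ccc2[nH]c(-c3ccccc3)c(C=C(C#N)C#N)c2c1` gives 7400 nM, compound 2 `CCOC(=O)C(=Cc1c(-c2ccccc2)[nH]c2ccccc12)C(=O)OCC` gives 4400 nM, and compound 3 `CC(=O)/C(=C\c1c(-c2ccccc2)[nH]c2ccccc12)S(=O)(=O)c1ccccc1` gives 1800 nM. Compound 3 therefore stands lowest of the three, with the gap to compound 2 and the larger gap to compound 1 both beyond the scatter. Compound 4 `N#C/C(=C\c1c(-c2ccccc2)[nH]c2ccccc12)S(=O)(=O)c1ccccc1` differs from compound 3 in one place: cyano in place of acetyl on a double-bonded chain carbon bound to a double-bonded chain carbon and a sulfonyl sulfur. Among the measured compounds shown here, no measured pair shows this exchange, so the step from compound 3 to compound 4 in this assay is expected to be small, at most modest and towards a weaker inhibitor, as a 1.4-fold higher number from compound 3 to compound 4 (0.14 log units; within the scatter). Compound 4 is accordingly estimated at 2500 nM, within a range from 800 nM to 8000 nM.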

Compound 4, concentration for 50% growth inhibition: 7000 nM
Beside the measured number, compound 4's estimate is 2.8-fold (0.45 log units) below it; measured number inside the range.
By their numbers in this assay, from the lowest: compound 3; then compounds 2, 4 and 1 (each within the scatter of the next).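

In this assay, the group on the double-bonded chain carbon bound to a double-bonded chain carbon and a sulfonyl sulfur matters: cyano in place of acetyl gives a 3.9-fold higher number from compound 3 to compound 4 (0.59 log units; beyond the scatter). This is the only change at a single place among the compounds shown, so it is the first direct sign that this position responds to substitution. No available evidence explains why the number rises. Going by these compounds, whether a carboxylic acid, an amide or a longer chain ketone at this place would give a lower or higher number remains open.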